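From Thiophene to Methoxyphenyl on a Shared Core

The source may hold more compounds than are shown below. What is called first, only, known or untested is meant among the compounds shown, and "the series" means these compounds.

The measured compounds and their values in an assay on isolated protein for agonist activity at Bile acid receptor (Homo sapiens), read by AlphaScreen, with a stated time of 30 min; a lower number here means that less compound is needed, a higher number that more compound is needed for the effect:
compound 1 `COc1cccc(-c2ccc([C@H]3S[C@@H](C)C(=O)Nc4c3c(C)nn4-c3ccccc3C)cc2)c1` gives 1800 nM
compound 2 `Cc1ccccc1-n1nc(C)c2c1NC(=O)[C@H](C)S[C@@H]2c1ccc(-c2cc3ccccc3o2)cc1` gives 1500 nM
compound 3 `Cc1ccccc1-n1nc(C)c2c1NC(=O)[C@H](C)S[C@@H]2c1ccc(-c2ccsc2)cc1` gives 1400 nM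

Compound 3 holds the lowest of the three numbers, yet the steps of a 1.1-fold lower number from compound 2 to compound 3 (0.03 log units; within the scatter) and a 1.3-fold lower number from compound 1 to compound 3 (0.11 log units; within the scatter) both lie within the scatter, so compound 3 cannot be set apart from the other two. All three share the same core and differ only in the group on the aromatic carbon para to a large group.

Compound 4 `COc1ccccc1-c1ccc([C@H]2S[C@@H](C)C(=O)Nc3c2c(C)nn3-c2ccccc2C)cc1` carries the change (2-methoxyphenyl in place of thiophen-3-yl on an aromatic carbon). The step that bears on it most is a 1.3-fold lower number from compound 1 to compound 3 (0.11 log units; within the scatter), where a 3-methoxyphenyl gave way to the thiophen-3-yl, with no movement beyond the scatter; the step of a 1.2-fold lower number from compound 1 to compound 2 (0.08 log units; within the scatter) tells the same story for a third group at this position. Among the compounds with values here, no measured compound carries a 2-methoxyphenyl, so that variant is untested. Compound 4 is therefore expected to show no step beyond the scatter, a 1.2-fold higher number from compound 3 to compound 4 (0.08 log units; within the scatter). For compound 4 the estimated value is 1700 nM, with a range from 800 nM to 3600 nM.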

Compound 4, half-maximal effective concentration: 1100 nM
Estimate against measurement, compound 4: 1.5-fold (0.19 log units) above; the range from low to high includes it.
By their numbers in this assay, from the lowest: compounds 4, 3, 2 and 1 (each within the scatter of the next).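

The step of a 1.3-fold lower number from compound 3 to compound 4 (0.10 log units; within the scatter) stands with a 1.4-fold lower number from compound 2 to compound 4 (0.13 log units; within the scatter) and a 1.6-fold lower number from compound 1 to compound 4 (0.21 log units; within the scatter) in this assay and adds a fourth aromatic group at this place with no step beyond the scatter. The last of these steps is the first comparison of two methoxyphenyl groups, and exchanging 3-methoxyphenyl for 2-methoxyphenyl does not separate the two compounds, so where the methoxy group stands on this phenyl ring makes no readable difference among the compounds shown. Nothing available here accounts for these results.

On these data alone, all four groups at this place are aromatic rings, so it remains open whether an amine, a carboxylic acid or a longer alkyl chain on this carbon would give a step beyond the scatter. The compounds shown also leave open how changes elsewhere on the shared core would affect the number.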